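Solubility of an extended amine side chain in this series

A few compounds are considered here, and "the series" means these few. Any claim that something is new, unique, unknown or untested is made for them only; others in the source may bear on it.

Of the compounds shown here, three of one shared core have been measured in a physicochemical assay for solubility, read by HPLC, in phosphate buffer, at pH 6.5 (a higher number here means a more soluble compound, a lower number a less soluble compound), so far. Compound 1 `NCCCNc1nnc(-c2ccc(F)c(F)c2Nc2ccc(I)cc2F)o1` gives 5.4 ug/mL in this assay. Compound 2 `CNCCNc1nnc(-c2ccc(F)c(F)c2Nc2ccc(I)cc2F)o1` gives 6.7 ug/mL in this assay, and a 1.2-fold higher number from compound 1 to compound 2 (0.09 log units; within the scatter). Within the data shown here, compound 3 `NCCNc1nnc(-c2ccc(F)c(F)c2Nc2ccc(I)cc2F)o1` sits at the limit of this assay, < 3 ug/mL, so only a floor is known for it; this is the single compound whose reading is a limit (the limit of < 3 ug/mL in this assay, at which 1 of the 3 values shown sits). Relative to the others, an at least 1.8-fold lower number from compound 1 to compound 3 (0.25 log units; that floor lies within the scatter) and an at least 2.2-fold lower number from compound 2 to compound 3 (0.34 log units; beyond the scatter).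

Compound 4 `CCN(CC)CCCNc1nnc(-c2ccc(F)c(F)c2Nc2ccc(I)cc2F)o1` differs from compound 3 in one place: (diethylamino)methyl in place of amino on a saturated chain carbon, two bonds along the chain from a nitrogen on an aromatic ring. Among the measured compounds shown here, the steps that bear on it are the two leading into compound 3, both of which read lower as the chain loses carbon and, in one case, the methyl on the amine nitrogen. Going the other way, toward a longer chain carrying a tertiary amine, the step is expected to move upward, an at least 3.0-fold higher number from compound 3 to compound 4 (0.47 log units; beyond the scatter). Compound 4 is therefore estimated at 9 ug/mL in this assay, with a range from 3 ug/mL to 25 ug/mL.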

Compound 4, solubility: < 3 ug/mL
Compound 4: no number, only a limit (the forecaster's own chance of this, stated with the estimate: 20%); middle value at least 3.0-fold (0.47 log units) from the limit.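

In this assay compound 4 gives < 3 ug/mL, a limit of the assay and not a number, so a tertiary amine on the longer chain reads at the same limit as compound 3: the limit of < 3 ug/mL in this assay, at which 2 of the 4 values shown sit. The diethylamino change brings no rise at this position, and the data show an at least 2.2-fold lower number from compound 2 to compound 4 (0.34 log units; beyond the scatter) and an at least 1.8-fold lower number from compound 1 to compound 4 (0.25 log units; that floor lies within the scatter). Among these compounds, no step between compound 3 and compound 4 can be read, as both readings are limits.

The compounds shown leave open how far compound 3 and compound 4 lie from that limit, and so whether they differ at all. They also do not separate the two ethyl groups from the rest of the change, which a dimethylamino group or a morpholine on the same propyl chain could address.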